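Compound 3 to compound 4: a tert-butyl swap

The compounds below may be only part of what the source reports. "The series", "measured", "known", "first", "only" and "open" are said of these compounds alone.

In a functional assay on BGC-823 cells (Homo sapiens) for inhibition, read by MTT assay, with a stated time of 72 h (on this read-out lower numbers stand for stronger inhibition and higher numbers for weaker inhibition), compound 1 (`Cc1ccc(CN2CCc3ncn(COCc4ccccc4)c3/C(=C/c3ccccc3)C2=O)cc1`) gives 39100 nM and compound 2 (`Cc1cc(C)cc(CN2CCc3ncn(COCc4ccccc4)c3/C(=C/c3ccccc3)C2=O)c1`) gives 52600 nM while compound 3 (`Cc1ccccc1CN1CCc2ncn(COCc3ccccc3)c2/C(=C/c2ccccc2)C1=O`) gives 31300 nM and so stands level with both (a 1.2-fold lower number from compound 1 to compound 3 (0.10 log units; within the scatter) and a 1.7-fold lower number from compound 2 to compound 3 (0.23 log units; within the scatter)). The remaining measured step (a 1.3-fold higher number from compound 1 to compound 2 (0.13 log units; within the scatter)) is equally small. The unmeasured compound 4 (`CC(C)(C)c1ccc(CN2CCc3ncn(COCc4ccccc4)c3/C(=C/c3ccccc3)C2=O)cc1`) has 4-(tert-butyl)phenyl in place of 2-methylphenyl on a saturated chain carbon bound to an amide-type nitrogen in a ring. Going by the values given here, the three measured steps exchange only methyl-bearing phenyl groups, and no measured compound carries tert-butyl, so they bear on this change only indirectly. In this assay the expected change is a 1.3-fold higher number from compound 3 to compound 4 (0.11 log units; within the scatter) (nothing beyond the scatter). For compound 4 the estimate is 40000 nM (range 18000 nM to 85000 nM).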

Compound 4, half-maximal inhibitory concentration: 27800 nM
The estimate for compound 4 lay 1.4-fold (0.16 log units) above the measured number; measured number inside the range.
By their numbers in this assay, from the lowest: compounds 4, 3, 1 and 2 (each within the scatter of the next).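

In this assay, 4-(tert-butyl)phenyl on a saturated chain carbon bound to an amide-type nitrogen in a ring leaves the number level with all three methyl-bearing groups (a 1.1-fold lower number from compound 3 to compound 4 (0.05 log units; within the scatter)), (a 1.9-fold lower number from compound 2 to compound 4 (0.28 log units; within the scatter)) and (a 1.4-fold lower number from compound 1 to compound 4 (0.15 log units; within the scatter)). This place therefore accepts a substituent of 10 heavy atoms as well as the smaller methyl-bearing phenyl groups, with no step beyond the scatter. Nothing available explains this flatness. All four groups here are carbon-only. From the compounds shown here alone, whether an amine, a carboxylic acid or a pyridine ring at this place would move the number beyond the scatter remains open.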